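Spiro series: ester-linked tetramethylpiperidine in place of sulfonamide

A few compounds are considered here, and "the series" means these few. Any claim that something is new, unique, unknown or untested is made for them only; others in the source may bear on it.

Going by the values given here, in an assay on HEK293 cells for displacement of a labelled ligand from NPC1-like intracellular cholesterol transporter 1 (Homo sapiens) (a higher number here means a weaker inhibitor, a lower number a stronger inhibitor), compound 2 `CC(C)(C)c1ccc(C(=O)N2CCC3(CC2)C(=O)N(CC(=O)NCNS(C)(=O)=O)CN3c2ccccc2)cc1` gives 3200 nM, the lowest of the two numbers so far; compound 1 `CC(C)(C)c1ccc(C(=O)N2CCC3(CC2)C(=O)N(CC(=O)NCCC(=O)O)CN3c2ccccc2)cc1` gives 11400 nM, the only measured step being a 3.6-fold lower number from compound 1 to compound 2 (0.55 log units; beyond the scatter). Compound 3 `CC1(C)CC(OC(=O)CN2CN(c3ccccc3)C3(CCN(C(=O)c4ccc(C(C)(C)C)cc4)CC3)C2=O)CC(C)(C)N1` carries (2,2,6,6-tetramethylpiperidin-4-yl)oxy in place of ((methanesulfonamido)methyl)amino on a carbonyl carbon. Among the compounds with values here, that step exchanged only the terminal group on the chain, whereas the change to compound 3 replaces the whole amino chain by an ester-linked ring, so no measured step bears on it and the direction is open. For compound 3 a number near compound 2 is expected, a 1.1-fold lower number from compound 2 to compound 3 (0.03 log units; within the scatter), with the estimate 3000 nM and range 800 nM to 12000 nM.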

Compound 3, half-maximal inhibitory concentration: 1300 nM
For compound 3 the middle estimate is 2.3-fold (0.36 log units) above the measured one, and the stated range covers the measured number.
By their numbers in this assay, from the lowest: compound 3; then compound 2; then compound 1.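

In this assay the carbonyl carbon accepts replacement of the whole amino chain, not just its terminal group: (2,2,6,6-tetramethylpiperidin-4-yl)oxy gives a 2.5-fold lower number from compound 2 to compound 3 (0.39 log units; beyond the scatter) and also an 8.8-fold lower number from compound 1 to compound 3 (0.94 log units; beyond the scatter). Neither the sulfonamide nor the carboxylic acid is needed at this position for binding, and compound 3 has the lowest number of the three. No evidence bears on why the number falls. The ester oxygen and the ring entered together, so their contributions remain unseparated. An amide-linked tetramethylpiperidine or an unsubstituted piperidine ester would separate them.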